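Swapping the benzylic substituent on a triazinone thioether

The source may report more compounds than this note shows. Statements on the series, on what has been measured and on what is new or still open speak of the compounds shown alone.

Compound 1 `COc1nc(OC)nc(Sc2ccccc2C(=O)O)n1` gives -14.3% in an assay for inhibition of Pro-cathepsin H (Homo sapiens), read by fluorescence, tested at 50 uM (a lower number here means less inhibition, a higher number more inhibition at the concentration tested (going by the name of the read-out)), essentially no inhibition. Compound 2 `N#Cc1cccc(CSc2nc(SCc3ccccc3)nc(=O)[nH]2)c1` has no single number to stand on: its result in this assay is "not determined" (no result reported). Compound 3 `O=c1nc(SCc2ccccc2)nc(SCC2CCCC2)[nH]1` is not yet measured. It differs from compound 2 by cyclopentyl in place of 3-cyanophenyl on a saturated chain carbon bound to a sulfur. Going by the values given here, with no measured step to lean on, no shift beyond the usual scatter is expected in this assay. Compound 3 is therefore estimated at 0%, within a range of -20% to 20%, reflecting the near-absent inhibition seen for compound 1.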

Compound 3, a percentage reported as inhibition, at one concentration (the size of the read-out at that concentration, not a potency): 10.6%
Compound 3: middle estimate off by 10.6 percentage points, on the low side, and the stated range covers the measured number.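

In this assay, going by these compounds alone, compound 2 has no single number, so no step from it to compound 3 can be read. Whether cyclopentyl in place of 3-cyanophenyl shifts inhibition stays open, and no evidence shown bears on the result.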